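Adding a Hydroxy Group to the Sugar of Compound 3

The compounds below may be only part of what the source reports. "The series", "measured", "known", "first", "only" and "open" are said of these compounds alone.

Of the compounds shown here, three sharing one core have been tested in a functional assay on HCT-116 cells (Homo sapiens) for cytotoxicity, read by MTT assay, with a stated time of 72 h; a lower number here means a stronger inhibitor, a higher number a weaker inhibitor. Compound 1 `CC1(C)O[C@@H](CO)[C@H](Cn2cc(Cn3c4c(c5ccccc53)C(=O)c3c[n+]([O-])c5ccccc5c3C4=O)nn2)O1` gives 130 nM. Compound 2 `CC1(C)OCC(Cn2cc(Cn3c4c(c5ccccc53)C(=O)c3c[n+]([O-])c5ccccc5c3C4=O)nn2)O1`, which carries 2,2-dimethyl-1,3-dioxolan-4-yl in place of 5-(hydroxymethyl)-2,2-dimethyl-1,3-dioxolan-4-yl, gives 70 nM, a change of a 1.9-fold lower number from compound 1 to compound 2 (0.27 log units; within the scatter). Compound 3 `O=C1c2c[n+]([O-])c3ccccc3c2C(=O)c2c1c1ccccc1n2Cc1cn([C@@H]2C[C@H](O)[C@@H](CO)O2)nn1` gives 50 nM, the lowest number of the three; the two steps leading to it are a 1.4-fold lower number from compound 2 to compound 3 (0.15 log units; within the scatter) and a 2.6-fold lower number from compound 1 to compound 3 (0.41 log units; beyond the scatter).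

Compound 4 `O=C1c2c[n+]([O-])c3ccccc3c2C(=O)c2c1c1ccccc1n2Cc1cn([C@H]2O[C@H](CO)[C@@H](O)[C@H]2O)nn1` differs from compound 3 in one place: hydroxy in place of hydrogen on a saturated ring carbon. Among the compounds with values here, no measured step repeats this exact change. The step from compound 1 to compound 2, which removed a hydroxymethyl group from the sugar part, stayed within the scatter, and the step from compound 2 to compound 3, which reshaped the sugar and brought in a hydroxy group, also stayed within the scatter. Variations in this part of the molecule have therefore produced only small movements so far, and compound 4 is expected to give 50 nM, with a likely range from 25 nM to 100 nM. Under this estimate the expected step is no change at the digits printed from compound 3 to compound 4 (within the scatter), which would lie within the scatter.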

Compound 4, half-maximal inhibitory concentration: 710 nM
For compound 4 the middle estimate is 14-fold (1.15 log units) below the measured one; the whole stated range lies below it.
By their numbers in this assay, from the lowest: compounds 3, 2 and 1 (each within the scatter of the next, the first and the last beyond it); then compound 4.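

In this assay the sugar part proves far less tolerant than compounds 1, 2 and 3 suggested: hydroxy in place of hydrogen on a saturated ring carbon, next to the ring atom that bears a large group, gives a 14-fold higher number from compound 3 to compound 4 (1.15 log units; beyond the scatter), the largest step in this set. The rise also holds against the other two compounds, with a 10-fold higher number from compound 2 to compound 4 (1.01 log units; beyond the scatter) and a 5.5-fold higher number from compound 1 to compound 4 (0.74 log units; beyond the scatter), so the 3,4-dihydroxy-5-(hydroxymethyl)oxolan-2-yl group of compound 4 places it apart from all three, beyond the scatter of each. No measured property is available to explain this rise, so it stands as an observation only.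

The compounds shown leave open whether the rise is specific to hydroxy or would also follow a methoxy group, a fluorine atom or an amine on the same ring carbon. They also leave open whether a hydroxy group on this carbon with the opposite stereochemistry would give a similar number, and whether the same change would have a step of this size in any other assay.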